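The source may hold more compounds than are shown below. What is called first, only, known or untested is meant among the compounds shown, and "the series" means these compounds.

Measured so far in a physicochemical assay for inhibition, read by colorimetric assay, tested at 1 mg/mL; a higher number here means more inhibition at the concentration tested (going by the name of the read-out), a lower number less inhibition:

compound 1 `COc1ccc(/C=C2\CCCC3C2=NN(C2=NC(=O)/C(=C/c4ccc(OC)c(OC)c4)S2)C3c2ccc(OC)cc2)cc1` gives 19.1%
compound 2 `COc1ccc(/C=C2\CCC3C2=NN(c2nc(-c4ccc(Cl)cc4)cs2)C3c2ccc(OC)cc2)cc1` gives 27.5%
compound 3 `COc1ccc(/C=C/C2=NN(C(N)=S)C(c3ccc(OC)cc3)C2)cc1` gives 84.5%

Compound 3 stands highest of the three numbers in this assay. The nearest to it is compound 2, whose value is lower by a margin beyond the usual scatter of repeated measurements; the furthest is compound 1, lower still, also beyond the scatter. Among the measured compounds shown here, no two of the three compounds differ in a single place, so no step between measured compounds can be stated; what is seen is only that the thiocarbamoyl-bearing compound 3 sits well above the two aryl-thiazole and thiazolone compounds, which have a different, fused core.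

Compound 4 `COc1ccc(/C=C/C2=NN(c3nc(-c4ccccc4)cs3)C(c3ccc(OC)cc3)C2)cc1` differs from compound 3 in one place: a group of 11 heavy atoms (9 carbon, 1 nitrogen, 1 sulfur; one five-membered aromatic ring with 2 hetero atoms, one six-membered aromatic ring of carbon only) in place of a group of 3 heavy atoms (1 carbon, 1 nitrogen, 1 sulfur; no ring), on an amine nitrogen in a ring.

For the measured compounds named here, no measured step covers this change. Compound 2 carries a related 4-aryl-thiazol-2-yl group on its ring nitrogen and gives 27.5% in this assay, but its core is not that of compound 3, so the comparison is indirect. The expectation is nonetheless a downward step, a number 44.5 percentage points lower from compound 3 to compound 4 (beyond the scatter), of a size beyond the scatter. Compound 4 is expected to give 40% in this assay, with a range from 15% to 70%.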

Compound 4, a percentage reported as inhibition, at one concentration (the size of the read-out at that concentration, not a potency): 76%
The estimate for compound 4 lay 36 percentage points below the measured number; the whole stated range lies below it.
By their numbers in this assay, from the lowest: compounds 1 and 2 (each within the scatter of the next); then compounds 4 and 3 (each within the scatter of the next).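

In this assay the exchange on the amine nitrogen in a ring, with 4-phenyl-1,3-thiazol-2-yl taking the place of the group of 3 heavy atoms that has no ring, gives a number 8.5 percentage points lower from compound 3 to compound 4 (within the scatter), so this position accepts a far larger group with two aromatic rings and no hydrogen-bond donor, without a change that can be told from scatter. Among the compounds shown here, this is the first single-place step, and it shows that on this core the loss of the hydrogen-bond donor and the added size together leave the read-out unchanged within scatter. Nothing at hand bears on why the number holds at this position.

Open, as far as these compounds go, is whether the same position also accepts groups of another kind, such as a carboxylic acid or a simple amine in place of the 4-phenyl-1,3-thiazol-2-yl, and whether a hydroxyl on its phenyl ring leaves the number where it stands. For the compounds shown here, also open is how this exchange reads on the core of compound 1 or compound 2, which differ from compound 3 and compound 4 in more than one place, so no step to them can be read.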